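This account rests on a few compounds, and the source may have more. Where it says the series, first, only, none or still open, it means among the compounds named here.

Compound 2 `CCOc1ccccc1N1CCN(CCCNC(=O)N2C(=O)NC(C)=C(C(=O)OC)C2c2ccc(F)c(F)c2)CC1` holds the lower of the two numbers recorded in an assay on liver for binding affinity to Alpha-1A adrenergic receptor (Homo sapiens), using microsomes; a higher number here means a weaker inhibitor, a lower number a stronger inhibitor: in this assay compound 2 gives 0.1 nM. Within the data shown here, its only measured neighbour is compound 1 `COC(=O)C1=C(C)NC(=O)N(C(=O)NCCCN2CCN(c3ccc(Cl)cc3)CC2)C1c1ccc(F)c(F)c1`, which in this assay gives 0.8 nM. Among the measured compounds shown here, the single step between them is an 8.0-fold lower number from compound 1 to compound 2 (0.90 log units; beyond the scatter); the two compounds differ only in the aryl group on the amine nitrogen in the ring. Compound 3 `COC(=O)C1=C(C)NC(=O)N(C(=O)NCCCN2CCN(c3cccc([N+](=O)[O-])c3)CC2)C1c1ccc(F)c(F)c1` alters the same position again: 3-nitrophenyl in place of 2-ethoxyphenyl on an amine nitrogen in a ring. For the measured compounds named here, only the step from compound 1 to compound 2 bears on this change, and it shows that exchanging the aryl group at this position can move the number by a modest amount. Because compound 2 gives 0.1 nM and thus the lowest number seen, the replacement of its aryl group is expected to raise the number somewhat, as written in a 5.0-fold higher number from compound 2 to compound 3 (0.70 log units; beyond the scatter). Compound 3 is therefore estimated to give 0.5 nM in this assay, within a range of 0.1 nM to 3 nM.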

Compound 3, inhibition constant: 12 nM
Estimate against measurement, compound 3: 24-fold (1.38 log units) below; measured number above the stated range.
By their numbers in this assay, from the lowest: compound 2; then compound 1; then compound 3.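

In this assay the aryl group on the amine nitrogen in the ring can move the number much further than the first pair suggested: 3-nitrophenyl in place of 2-ethoxyphenyl gives a 120-fold higher number from compound 2 to compound 3 (2.08 log units; beyond the scatter), and 3-nitrophenyl in place of 4-chlorophenyl gives a 15-fold higher number from compound 1 to compound 3 (1.18 log units; beyond the scatter). Both steps are large, and they place the 3-nitrophenyl compound highest of the three, so this change costs more than the exchange of 4-chlorophenyl for 2-ethoxyphenyl gained. Nothing available accounts for the size of these steps.

Each of the three aryl groups differs both in its substituent and in that substituent's place on the phenyl ring, so the two effects remain tied together; a 2-nitrophenyl or a 3-ethoxyphenyl group would pull them apart. Also open, going by these compounds, is how a plain phenyl or a 3-aminophenyl group would stand.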